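Inverting the Chain Stereocentre: From Compound 3 to Compound 4

The compounds below may be only part of what the source reports. "The series", "measured", "known", "first", "only" and "open" are said of these compounds alone.

Compound 1 `CC(C(=O)NCc1ccc(C(C)(C)C)nc1N1CCCC1)c1ccc(NS(C)(=O)=O)c(F)c1`: 1.2 nM
Compound 2 `CC(C(=O)NCc1ccc(C(C)(C)C)cc1SC1CCCCC1)c1ccc(NS(C)(=O)=O)c(F)c1`: 7.4 nM
Compound 3 `C[C@@H](C(=O)NCc1ccc(C(C)(C)C)cc1SC1CCCCC1)c1ccc(NS(C)(=O)=O)c(F)c1`: 89.2 nM

Within the data shown here, in an assay on cells for antagonist activity at transient receptor potential cation channel subfamily V member 1 (Homo sapiens), read by FLIPR and calcium flux, with a stated time of 6 min (on this read-out lower numbers stand for stronger inhibition and higher numbers for weaker inhibition), compound 3 gives the highest number of the three, and the one step measured alongside it, a 12-fold higher number from compound 2 to compound 3 (1.08 log units; beyond the scatter), is large. Compound 1 gives 1.2 nM, and compound 2 gives 7.4 nM.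

Compound 4 `C[C@H](C(=O)NCc1ccc(C(C)(C)C)cc1SC1CCCCC1)c1ccc(NS(C)(=O)=O)c(F)c1` differs from compound 3 by the two compounds have the same atoms and bonds and differ only in configuration as drawn: 1 of 1 stereo elements differ; a stereocentre at a saturated chain carbon is drawn R in compound 3 and S in compound 4. Among the measured compounds shown here, the only measured step that bears on this change is a 12-fold higher number from compound 2 to compound 3 (1.08 log units; beyond the scatter), and it is read together with the fact that one of compounds 2 and 3 is drawn with a defined configuration and the other without, at the place where they differ. On that basis the inversion in this assay is expected to move the number down substantially, by the step of a 22-fold lower number from compound 3 to compound 4 (1.35 log units; beyond the scatter). Compound 4 is therefore estimated at 4 nM, with a range from 1.5 nM to 12 nM.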

Compound 4, inhibition constant: 6 nM
Compound 4: middle estimate off by 1.5-fold (0.18 log units), on the low side; low and high end bracket the measured number.
By their numbers in this assay, from the lowest: compound 1; then compounds 4 and 2 (each within the scatter of the next); then compound 3.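

In this assay the inversion shows that the drawn configuration at this saturated chain carbon matters, with a 15-fold lower number from compound 3 to compound 4 (1.17 log units; beyond the scatter): the fact that compounds 3 and 4 differ only in the configuration as drawn The S form cannot be told apart from the compound drawn without a configuration, with a 1.2-fold lower number from compound 2 to compound 4 (0.09 log units; within the scatter): the fact that one of compounds 2 and 4 is drawn with a defined configuration and the other without, at the place where they differ Of the two drawn forms, only the R form, compound 3, stands beyond the scatter from compound 2.

From the compounds shown here alone, it remains open whether S and R separate in the same way on the core of compound 1. Going by these compounds, it is also open how a longer chain or a carboxylic acid at this stereocentre would compare with compound 4.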